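The source may report more compounds than this note shows. Statements on the series, on what has been measured and on what is new or still open speak of the compounds shown alone.

Measured so far in a functional assay on the whole organism for inhibition, with Mus musculus as the target, at a dose of 25 mg/kg by the oral route; a lower number here means less inhibition, a higher number more inhibition at the dose given (going by the name of the read-out): compound 1 `Fc1cccc(N2CCN(CCCOc3ccc4c(c3)CCC4)CC2)c1` gives 42%; compound 2 `Fc1ccc(N2CCN(CCCCCOc3ccc4c(c3)CCC4)CC2)cc1` gives 71%; compound 3 `Clc1cc(Cl)cc(N2CCN(CCCCOc3ccc4c(c3)CCC4)CC2)c1` gives 0%.

Compound 1 stands second highest of the three numbers. Its nearest neighbour is compound 2, whose number lies higher by more than the usual scatter, and the furthest is compound 3, whose number lies lower by more than the scatter. Compound 4 `O=[N+]([O-])c1ccc(N2CCN(CCCOc3ccc4c(c3)CCC4)CC2)cc1` has not yet been measured. It differs from compound 1 in one place: 4-nitrophenyl in place of 3-fluorophenyl on an amine nitrogen in a ring. Among the compounds with values here, no two measured compounds differ in only one place, so the size of such a change is not known from these data, and compounds 2 and 3 each differ from compound 1 in more than one place. The step of a number 2 percentage points lower from compound 1 to compound 4 (within the scatter) is expected to stay within the scatter, with wide uncertainty. Compound 4 is estimated at 40%, between 10% and 70%.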

Compound 4, a percentage reported as inhibition, in the whole organism at one dose (the size of the read-out at that dose, not a potency): 26%
Estimate against measurement, compound 4: 14 percentage points above; low and high end bracket the measured number.
By their numbers in this assay, from the lowest: compound 3; then compound 4; then compound 1; then compound 2.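

In this assay, within the data shown here, this is the first comparison in which only one place changes, and it gives a size for a change on the amine nitrogen in the ring: 4-nitrophenyl in place of 3-fluorophenyl gives a number 16 percentage points lower from compound 1 to compound 4 (beyond the scatter). With the rest of the molecule held the same, the read-out therefore responds to the aryl group at this position. Nothing available explains this step. The compounds shown leave open whether the substituent or its ring position matters, as both change together. From the compounds shown here alone, whether a plain phenyl or 3-nitrophenyl on the same core would separate the two also remains open.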